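Removing 3-methylbut-2-en-1-yl from compound 3

The source may hold more compounds than are shown below. What is called first, only, known or untested is meant among the compounds shown, and "the series" means these compounds.

Values in a functional assay on J774.A1 cells (Mus musculus) for inhibition, read by Griess assay, with stated times of 1 h and 24 h (on this read-out lower numbers stand for stronger inhibition and higher numbers for weaker inhibition), so far:
- compound 1 `O=C1CC(c2ccccc2OCc2ccc(F)cc2)Oc2ccccc21` gives 25500 nM
- compound 2 `C=CCOc1ccccc1C1CC(=O)c2ccccc2O1` gives 38600 nM
- compound 3 `CC(C)=CCOc1ccccc1C1CC(=O)c2ccccc2O1` gives 34300 nM

Compound 3 stands within the scatter of both others, with a 1.1-fold lower number from compound 2 to compound 3 (0.05 log units; within the scatter) and a 1.3-fold higher number from compound 1 to compound 3 (0.13 log units; within the scatter) as its steps. Compound 4 `O=C1CC(c2ccccc2O)Oc2ccccc21` carries hydrogen in place of 3-methylbut-2-en-1-yl on an oxygen on an aromatic ring, a difference counted as hydrogen in place of 3-methylbut-2-en-1-yl on an oxygen on an aromatic ring and not yet measured. The nearest evidence is those two steps and a 1.5-fold higher number from compound 1 to compound 2 (0.18 log units; within the scatter), all within the scatter. Each exchanges only a group on a saturated chain carbon bound to an oxygen on an aromatic ring, and none puts hydrogen on that oxygen, so the evidence is indirect. No step beyond the scatter is expected in this assay, in either direction. The expected step is a 1.1-fold lower number from compound 3 to compound 4 (0.06 log units; within the scatter), with wide uncertainty. For compound 4 the estimated value is 30000 nM, with an expected range from 10000 nM to 90000 nM.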

Compound 4, half-maximal inhibitory concentration: 71300 nM
The estimate for compound 4 lay 2.4-fold (0.38 log units) below the measured number; measured number inside the range.
By their numbers in this assay, from the lowest: compounds 1, 3, 2 and 4 (each within the scatter of the next, the first and the last beyond it).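

Within the data shown here, compound 4 is the first compound in this assay with hydrogen on the oxygen on an aromatic ring, and it shows that this position can respond, whereas the earlier exchanges of one group for another on that oxygen did not move the number beyond the scatter. Replacing the groups gives a 2.1-fold higher number from compound 3 to compound 4 (0.32 log units; beyond the scatter) and a 2.8-fold higher number from compound 1 to compound 4 (0.45 log units; beyond the scatter) as steps beyond the scatter, while a 1.8-fold higher number from compound 2 to compound 4 (0.27 log units; within the scatter) stays within it and goes against any general loss on removal. No evidence given here accounts for these steps.

On these data alone, whether an amine or a carboxylic acid on this chain, or a longer chain, would give a lower number than 4-fluorobenzyl remains open.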